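Replacing a methoxyphenyl with thiophene in a sulfonamide series

The compounds below may be only part of what the source reports. "The series", "measured", "known", "first", "only" and "open" are said of these compounds alone.

Two compounds sharing the same sulfonamide core have been characterised in a functional assay for agonist activity at growth hormone secretagogue receptor type 1 (Homo sapiens), read by FLIPR; on this read-out higher numbers stand for an effect only at larger amounts of compound and lower numbers for an effect already at smaller amounts. Compound 1 `C[C@@H]1CN(c2ccc(F)c(NS(=O)(=O)c3ccc(-c4ccccn4)s3)c2)C[C@H](C)N1` gives 100 nM in this assay. Compound 2 `COc1cccc(-c2ccc(S(=O)(=O)Nc3cc(N4C[C@@H](C)N[C@@H](C)C4)ccc3OC)cc2)c1` gives 2 nM in this assay, the lowest of the two numbers, and its gap to compound 1 lies beyond the usual scatter. The next member, compound 3 `COc1ccc(N2C[C@@H](C)N[C@@H](C)C2)cc1NS(=O)(=O)c1ccc(-c2cccs2)cc1`, differs from compound 2 in one place: thiophen-2-yl in place of 3-methoxyphenyl on an aromatic carbon. Going by the values given here, no pair of measured compounds that differ in only one place is available to set the size of such a step, so the expectation rests on compound 2 alone with 2 nM as the anchor. The step from compound 2 to compound 3 is expected to be modest, toward a higher number, of the order of a 4.0-fold higher number from compound 2 to compound 3 (0.60 log units; beyond the scatter). Compound 3 is therefore estimated at 8 nM, within a range from 2 nM to 30 nM.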

Compound 3, half-maximal effective concentration: 3.98 nM
Compound 3: middle estimate off by 2.0-fold (0.30 log units), on the high side; the range from low to high includes it.
By their numbers in this assay, from the lowest: compounds 2 and 3 (each within the scatter of the next); then compound 1.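

In this assay, going by these compounds alone, thiophen-2-yl in place of 3-methoxyphenyl, on an aromatic carbon para to a large group, gives a 2.0-fold higher number from compound 2 to compound 3 (0.30 log units; within the scatter), the only step here that differs in one place. It shows that at this position a five-membered aromatic ring with 1 hetero atom and 5 heavy atoms can stand in for a six-membered aromatic ring of carbon only with 8 heavy atoms, with no difference that can be told from the scatter. Nothing available bears on why the two groups read alike.

As far as these compounds go, it remains open whether the methoxy group plays any part at this position, which a plain phenyl or a furan-2-yl there would help to settle. From the compounds shown here alone, it is also open how a group of another kind, such as a carboxylic acid or an aminomethyl group on that ring, would read out.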